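This account rests on a few compounds, and the source may have more. Where it says the series, first, only, none or still open, it means among the compounds named here.

Measured in a functional assay on MCF7 cells (Homo sapiens) for antiproliferative activity, read by MTT assay, with a stated time of 48 h; a higher number here means a weaker inhibitor, a lower number a stronger inhibitor:
- compound 1 `CC(C)=CCC[C@]1(C)/C=C/[C@@H](OC(=O)C=C(C)C)[C@](C)(O)/C=C/C(=O)/C(CF)=C\C1`: 240 nM
- compound 2 `CC(C)=CCC[C@]1(C)/C=C/[C@@H](OC(=O)C=C(C)C)[C@](C)(O)/C=C/C(=O)/C(CN(C(C)C)C(C)C)=C\C1`: 780 nM
- compound 3 `CC(C)=CCC[C@]1(C)/C=C/[C@@H](OC(=O)C=C(C)C)[C@](C)(O)/C=C/C(=O)/C(CN2CCN(C)CC2)=C\C1`: 550 nM

Compound 3 stands close to compound 2, with a 1.4-fold lower number from compound 2 to compound 3 (0.15 log units; within the scatter), while a 2.3-fold higher number from compound 1 to compound 3 (0.36 log units; beyond the scatter) sets it apart from the fluoro compound. Compound 4 `CC[Si](CC)(CC)C/C1=C/C[C@](C)(CCC=C(C)C)/C=C/[C@@H](OC(=O)C=C(C)C)[C@](C)(O)/C=C/C1=O` changes the same substituent: a group of 7 heavy atoms (6 carbon, 1 silicon; no ring) in place of a group of 7 heavy atoms (5 carbon, 2 nitrogen; one six-membered non-aromatic ring with 2 hetero atoms), on a saturated chain carbon bound to a double-bonded ring carbon. Among the measured compounds shown here, no measured compound carries silicon, which leaves only indirect evidence. For the measured compounds named here, the steps that bear on this change are a 3.3-fold higher number from compound 1 to compound 2 (0.51 log units; beyond the scatter) and those already given, and all of them are modest or smaller. A similar change at this place should therefore stay small in this assay. The estimated step, not expected to exceed the scatter, is a 1.4-fold lower number from compound 3 to compound 4 (0.14 log units; within the scatter). For compound 4 the expected value is 400 nM, with an estimated range of 150 nM to 1100 nM.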

Compound 4, half-maximal inhibitory concentration: 3150 nM
Beside the measured number, compound 4's estimate is 7.9-fold (0.90 log units) below it, outside the stated range (above it).
By their numbers in this assay, from the lowest: compound 1; then compounds 3 and 2 (each within the scatter of the next); then compound 4.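

Among the compounds shown here, the position tolerates less than the earlier compounds suggested: in this assay, the silicon-bearing group gives a 5.7-fold higher number from compound 3 to compound 4 (0.76 log units; beyond the scatter) and a 4.0-fold higher number from compound 2 to compound 4 (0.61 log units; beyond the scatter). For the compounds shown here, compounds 2, 3 and 4 carry groups with the same heavy-atom count, so that count alone does not set the number, and a 13-fold higher number from compound 1 to compound 4 (1.12 log units; beyond the scatter) is the first large step at this place. No measurement shown explains this gap. Still open, on these data alone, is whether the silicon atom or the lack of nitrogen matters more: an all-carbon group, with carbon in place of silicon, would separate the two.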